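The source may report more compounds than this note shows. Statements on the series, on what has been measured and on what is new or still open speak of the compounds shown alone.

Measured in a functional assay on L1210 cells (Mus musculus) for inhibition; a lower number here means a stronger inhibitor, a higher number a weaker inhibitor:
- compound 1 `Nc1ncnc2c1ncn2C=C=CCCl`: 45000 nM
- compound 2 `Nc1ncnc2c1ncn2CC#CCO`: 490000 nM

Compound 2 gives 490000 nM, the higher of the two numbers and so the weaker inhibitor of this pair. Compound 3 `Nc1ncnc2c1ncn2/C=C\CCO` keeps the shared core and changes only the chain on the aromatic nitrogen: 4-hydroxybut-1-en-1-yl in place of 4-hydroxybut-2-yn-1-yl on an aromatic nitrogen.

Among the measured compounds shown here, one measured step bears on this change, and only indirectly. The step of an 11-fold higher number from compound 1 to compound 2 (1.04 log units; beyond the scatter) is large and beyond the scatter, and it involves the same attachment point. However, it replaces 4-chlorobuta-1,2-dien-1-yl, whereas compound 3 and compound 2 both carry a chain with a hydroxy group. For the measured compounds named here, no measured pair isolates a triple bond against a double bond, so the large step in this assay cannot simply be carried over. No clear shift in either direction is expected, and a step within the scatter is the working expectation. The expected step is a 1.2-fold lower number from compound 2 to compound 3 (0.09 log units; within the scatter). For compound 3 the estimated value is 400000 nM, with an expected range of 130000 nM to 1000000 nM.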

Compound 3, half-maximal inhibitory concentration: 200000 nM
Compound 3: the middle estimate sits 2.0-fold (0.30 log units) above what was measured; measured number inside the range.
By their numbers in this assay, from the lowest: compound 1; then compound 3; then compound 2.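

In this assay, among the compounds shown here, compound 3 and compound 2 form the first pair that keeps the hydroxy end of the chain and changes only the unsaturated bond, and 4-hydroxybut-1-en-1-yl in place of 4-hydroxybut-2-yn-1-yl gives a 2.5-fold lower number from compound 2 to compound 3 (0.39 log units; beyond the scatter) as a modest step beyond the scatter. The chain on the aromatic nitrogen is therefore sensitive to this bond change even with its length in heavy atoms and its hydrogen-bond counts unchanged, but compound 1 with 4-chlorobuta-1,2-dien-1-yl still has the lowest number, with a 4.4-fold higher number from compound 1 to compound 3 (0.65 log units; beyond the scatter) as a further modest step. No available evidence accounts for either step.

Compound 1 differs from compound 2 and compound 3 in both the end of the chain and its unsaturated bonds, so the contribution of the chlorine cannot be separated from that of the buta-1,2-dien-1-yl unit. The compounds shown also leave open how a saturated 4-hydroxybutyl chain, a terminal amine or a longer chain would compare in this assay with the 4-hydroxybut-1-en-1-yl chain of compound 3.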